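Side-chain swaps and acid dissociation in a small series

The source may hold more compounds than are shown below. What is called first, only, known or untested is meant among the compounds shown, and "the series" means these compounds.

Measured in a physicochemical assay for acid dissociation:
- compound 1 `CC#CCOc1noc2c1CNCC2`: 7.6
- compound 2 `CCCCOc1noc2c1CNCC2`: 7.6
- compound 3 `C=CCOc1noc2c1CNCC2`: 7.5

Compound 3, at 7.5, cannot be separated from the other two compounds, since its steps from both lie within the scatter. The next compound is compound 4 `CC(C)COc1noc2c1CNCC2`, which carries isopropyl in place of the vinyl of compound 3, on a saturated chain carbon bound to an oxygen on an aromatic ring: isopropyl in place of vinyl on a saturated chain carbon bound to an oxygen on an aromatic ring. Cut one bond further out, this reads allyl to isobutyl.

For the measured compounds named here, three measured steps bear on this change: a number 0.10 log units lower from compound 2 to compound 3 (within the scatter), a number 0.10 log units lower from compound 1 to compound 3 (within the scatter) and no change at the digits printed from compound 1 to compound 2 (within the scatter). All three are small and within the scatter. Isopropyl itself has no measurement in this series, so the evidence is indirect. The expected change is a number 0.10 log units higher from compound 3 to compound 4 (within the scatter), with nothing expected beyond the scatter. For compound 4 the estimated value in this assay is 7.6, with an expected range of 7.3 to 7.9.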

Compound 4, acid dissociation constant: 7.7
Beside the measured number, compound 4's estimate is 0.10 log units below it; the measured number falls inside the stated range.
By their numbers in this assay, from the lowest: compounds 3, 1, 2 and 4 (each within the scatter of the next).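

In this assay isopropyl, on a saturated chain carbon bound to an oxygen on an aromatic ring, gives no separation from any of the other three groups: from vinyl (a number 0.20 log units higher from compound 3 to compound 4 (within the scatter)), from propyl (a number 0.10 log units higher from compound 2 to compound 4 (within the scatter)) and from prop-1-yn-1-yl (a number 0.10 log units higher from compound 1 to compound 4 (within the scatter)). For the compounds shown here, all four compounds now stand within the scatter of one another, so this change adds a group with one more carbon than vinyl and no double bond, yet still no step that can be told from noise. No supporting data accompany these numbers to account for the flat result.

All the groups shown at this place contain carbon only, so the effect of an amine, a carboxylic acid or a much longer chain remains open. From the compounds shown here alone, whether any group at this place can move the number beyond the scatter also stays open.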